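Replacing the formyl group on the shared core

The source may hold more compounds than are shown below. What is called first, only, known or untested is meant among the compounds shown, and "the series" means these compounds.

The series is followed in a functional assay on MCF7 cells (Homo sapiens) for antiproliferative activity, with a stated time of 5 days; a higher number here means a weaker inhibitor, a lower number a stronger inhibitor. Going by the values given here, compound 1 `CCCCc1ccc2[nH]c(-c3ccc(OC)cc3)c(C=O)c2c1` gives 22 nM in this assay, the second highest of the three numbers measured so far. Compound 2 `CCCCCCc1ccc2[nH]c(-c3ccc(OC)cc3)c(C=O)c2c1` gives 6 nM, and compound 3 `CCCCc1ccc2[nH]c(-c3ccc(C)cc3)c(C=O)c2c1` gives 54 nM. The two steps measured from compound 1 are a 3.7-fold lower number from compound 1 to compound 2 (0.56 log units; beyond the scatter), with ethyl in place of hydrogen on a saturated chain carbon, and a 2.5-fold higher number from compound 1 to compound 3 (0.39 log units; beyond the scatter), with methyl in place of methoxy on an aromatic carbon.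

Compound 4 `CCCCc1ccc2[nH]c(-c3ccc(OC)cc3)c(/C=N\O)c2c1` has not yet been measured. It differs from compound 1 in a place untouched by the steps above: a group of 3 heavy atoms (1 carbon, 1 nitrogen, 1 oxygen; no ring) in place of a group of 2 heavy atoms (1 carbon, 1 oxygen; no ring), on an aromatic carbon. The formyl group leaves and is replaced on the same aromatic carbon of the five-membered aromatic ring of the shared core. Neither measured step concerns this part of the molecule; both deal with the chain or with the methoxy-bearing ring, so they give no direct guide to the size or direction of this change, and no comparable exchange exists in the set. The step of a 1.8-fold higher number from compound 1 to compound 4 (0.26 log units; within the scatter) is therefore expected to be modest at most, with a slight loss taken as somewhat more likely than a gain, and the uncertainty is wide. The estimate for compound 4 in this assay is 40 nM, in the range 10 nM to 160 nM.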

Compound 4, half-maximal inhibitory concentration: 212 nM
Estimate against measurement, compound 4: 5.3-fold (0.72 log units) below, outside the stated range (above it).
By their numbers in this assay, from the lowest: compound 2; then compound 1; then compound 3; then compound 4.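

Formyl on this aromatic carbon of the five-membered aromatic ring cannot be exchanged freely: in this assay the swap to the group of 3 heavy atoms gives a 9.6-fold higher number from compound 1 to compound 4 (0.98 log units; beyond the scatter) on a single change of the shared core. This is the first reading at this position, and the step is larger than both a 3.7-fold lower number from compound 1 to compound 2 (0.56 log units; beyond the scatter) at the chain and a 2.5-fold higher number from compound 1 to compound 3 (0.39 log units; beyond the scatter) at the methoxy-bearing ring, so among the places varied from compound 1, this one has shown the largest response so far. The change adds a nitrogen, 1 hydrogen-bond donor and a second hydrogen-bond acceptor at once, and nothing available accounts for the higher number.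

A single exchange cannot separate these differences, and a nitrile, a hydroxymethyl group or a carboxylic acid on the same aromatic carbon would show whether the higher number belongs to this particular group or to any loss of formyl. Going by these compounds, it also remains open whether the step from formyl to this group keeps its size when the longer chain of compound 2 or the methyl group of compound 3 is present.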